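Heptyl to 2-fluorophenyl: a small step in cytotoxicity

The source may hold more compounds than are shown below. What is called first, only, known or untested is meant among the compounds shown, and "the series" means these compounds.

Three compounds have been measured in an ADME assay on SK-OV-3 cells (Homo sapiens) for cytotoxicity, read by sulforhodamine B assay, with a stated time of 48 h, tested at 10 uM; a lower number here means less inhibition, a higher number more inhibition at the concentration tested (going by the name of the read-out):
Compound 1 `CCCCCCCc1cn(C(c2ccccc2)c2cc3cc(Br)ccc3nc2OC)nn1` gives 10.5%.
Compound 2 `COc1nc2ccc(Br)cc2cc1C(c1ccccc1)n1cc(-c2ccccc2)nn1` gives 13.7%.
Compound 3 `CCCCc1cn(C(c2ccccc2)c2cc3cc(Br)ccc3nc2OC)nn1` gives 11.1%.

Compound 1 has the lowest of the three numbers, yet the gaps to the others are small: a number 0.6 percentage points higher from compound 1 to compound 3 (within the scatter) and a number 3.2 percentage points higher from compound 1 to compound 2 (within the scatter), both within the scatter, so none of the three can be told apart.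

Compound 4 `COc1nc2ccc(Br)cc2cc1C(c1ccccc1)n1cc(-c2ccccc2F)nn1` is the next member. Compared with compound 1 the change is 2-fluorophenyl in place of heptyl on an aromatic carbon.

The step that bears on it most is the phenyl in place of heptyl, a number 3.2 percentage points higher from compound 1 to compound 2 (within the scatter), which stayed within the scatter; likewise a number 2.6 percentage points lower from compound 2 to compound 3 (within the scatter). A ring in place of a chain therefore left the read-out essentially unchanged, and the added fluorine is a small further change. Compound 4 is thus expected to sit near compound 1, with an estimated step of a number 2.5 percentage points higher from compound 1 to compound 4 (within the scatter), no larger than the scatter. The estimate for compound 4 is 13%, ranging from 4% to 24%.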

Compound 4, a percentage reported as inhibition, at one concentration (the size of the read-out at that concentration, not a potency): 7.33%
The estimate for compound 4 lay 5.7 percentage points above the measured number; the measured number falls inside the stated range.
By their numbers in this assay, from the lowest: compounds 4, 1, 3 and 2 (each within the scatter of the next).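

Putting fluoro in place of hydrogen on the phenyl ring gives a number 6.4 percentage points lower from compound 2 to compound 4 (within the scatter) in this assay, so this substitution on the ring does not separate the two compounds. Replacing a chain with 2-fluorophenyl gives a number 3.2 percentage points lower from compound 1 to compound 4 (within the scatter) and a number 3.8 percentage points lower from compound 3 to compound 4 (within the scatter), so heptyl, butyl, phenyl and 2-fluorophenyl at this position all remain within the scatter of one another. No measured evidence bears on why these steps are small. On these data alone, all four groups are alkyl chains or aromatic rings, so it remains open whether an amine or a carboxylic acid here would shift the read-out beyond the scatter.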